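Open amide pair: methyl to chloro on the benzamide ring

A few compounds are considered here, and "the series" means these few. Any claim that something is new, unique, unknown or untested is made for them only; others in the source may bear on it.

The series is followed in an assay on cells for inhibition of cytochrome P450 11B2, mitochondrial (Homo sapiens), read by HTRF; a lower number here means a stronger inhibitor, a higher number a weaker inhibitor. Compound 1 `CC1c2cc(Cl)ccc2C(=O)N1c1cccnc1` gives 123 nM there, and compound 3 `CCS(=O)(=O)NCc1cncc(N2C(=O)c3ccc(Cl)cc3C2(C)C)c1` gives 92 nM. Compound 2 `Cc1ccc(C(=O)Nc2cccnc2)cc1` is the open amide of the set. For compound 2 this assay reports only a limit, > 3000 nM, so compound 2 stands at the limit of > 3000 nM in this assay, at which 1 of the 3 values shown sits, and no number for it is known. Compound 4 `O=C(Nc1cccnc1)c1ccc(Cl)cc1` differs from compound 2 in a single place: chloro in place of methyl on an aromatic carbon. For the measured compounds named here, no step between two measured compounds is available, so there is no measured guide to how large such a swap turns out in this assay. The working expectation is that the change from compound 2 to compound 4 stays within the usual scatter, with compound 4 most likely again sitting at the limit. On that basis compound 4 is estimated at 3000 nM in this assay, with a range of 800 nM to 10000 nM. The step this estimate implies is a number no higher from compound 2 to compound 4 (the limit leaves the size open), expected to be no more than scatter.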

Compound 4, half-maximal inhibitory concentration: 420 nM
Beside the measured number, compound 4's estimate is 7.1-fold (0.85 log units) above it, and the stated range ends above it.
By their numbers in this assay, from the lowest: compounds 3 and 1 (each within the scatter of the next); then compound 4. At a limit, above all of these: compound 2.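

In this assay, for the compounds shown here, the open amide pair now gives the first measured step: chloro in place of methyl on an aromatic carbon yields an at least 7.1-fold lower number from compound 2 to compound 4 (0.85 log units; beyond the scatter). This position, para to a group of 9 heavy atoms, therefore responds to the change, since the exchange of one heavy atom for another moves the number beyond the scatter. The true size of the step stays unknown because compound 2 carries only a limit and not a number: the limit of > 3000 nM in this assay, at which 1 of the 4 values shown sits.

Only methyl and chloro are shown at this position, so the effect of a methoxy group, a nitrile or an amine there remains open. On these data alone, how compound 4 relates to compound 1 also remains open, as the two differ in more than one place.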